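Replacing the Thiadiazolylsulfanyl Arm with a Piperazinyl Enamine

The compounds below may be only part of what the source reports. "The series", "measured", "known", "first", "only" and "open" are said of these compounds alone.

Measured compounds:
compound 1 `Cn1c(-c2ccc(NC(=O)CSc3nc4ccccc4o3)cc2)nc(-c2ccccc2)c1-c1ccccc1` — 44.9%
compound 2 `Cc1nnc(SCC(=O)Nc2ccc(-c3nc(-c4ccccc4)c(-c4ccccc4)n3C)cc2)s1` — 73%

Among the measured compounds shown here, in a functional assay on HT-29 cells (Homo sapiens) for cytotoxicity, read by MTT assay, with a stated time of 24 h, tested at 6.4 ug/mL (a lower number here means a weaker effect, a higher number a stronger effect of the compound at the concentration tested), compound 2 gives 73%, the higher of the two numbers measured so far, with compound 1 as its nearest neighbour. For the measured compounds named here, the one step measured between these compounds, a number 28.1 percentage points higher from compound 1 to compound 2 (beyond the scatter), exchanges one heteroaryl on the sulfur for another and gives a modest rise.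

Compound 3 `CN(C)/C=C/N1CCN(CC(=O)Nc2ccc(-c3nc(-c4ccccc4)c(-c4ccccc4)n3C)cc2)CC1` differs from compound 2 by 4-(2-(dimethylamino)ethenyl)piperazin-1-yl in place of (5-methyl-1,3,4-thiadiazol-2-yl)sulfanyl on a saturated chain carbon bound to a carbonyl carbon. Going by the values given here, no measured step removes the (5-methyl-1,3,4-thiadiazol-2-yl)sulfanyl group itself; the step from compound 1 to compound 2 only varies the ring on that sulfur, so it bears on this change weakly at most. With nothing closer to go on, the expectation is a fall back toward the level of compound 1, a step estimated as a number 28 percentage points lower from compound 2 to compound 3 (beyond the scatter). Compound 3 is therefore expected to give about 45% in this assay, somewhere between 20% and 70%.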

Compound 3, a percentage reported as activity, at one concentration (the size of the read-out at that concentration, not a potency): 12.2%
Beside the measured number, compound 3's estimate is 32.8 percentage points above it, outside the stated range (below it).
By their numbers in this assay, from the lowest: compound 3; then compound 1; then compound 2.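

In this assay, the earlier step only varied the ring on the sulfur, whereas replacing the whole sulfur-linked arm with 4-(2-(dimethylamino)ethenyl)piperazin-1-yl on the saturated chain carbon bound to a carbonyl carbon gives a number 60.8 percentage points lower from compound 2 to compound 3 (beyond the scatter) and, against the benzoxazolyl arm, a number 32.7 percentage points lower from compound 1 to compound 3 (beyond the scatter). The read-out at this position therefore extends well below the level of both sulfur-linked compounds, and compound 3 stands lowest of the three. Nothing available explains this fall.

The compounds shown leave open whether the fall goes with the loss of the sulfur, the piperazine ring or the 2-(dimethylamino)ethenyl group, as all three change together in this single step. A plain piperazine, a 4-methylpiperazine or a morpholine in the same place would begin to separate these parts.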